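Swapping the Piperazine Substituent: From Pyridylmethyl to Cyanophenyl

A few compounds are considered here, and "the series" means these few. Any claim that something is new, unique, unknown or untested is made for them only; others in the source may bear on it.

Of the compounds shown here, two with a shared core have been tested in a functional assay on MGC-803 cells (Homo sapiens) for antiproliferative activity, read by CCK-8 assay, with a stated time of 72 h, tested at 2 uM; on this read-out lower numbers stand for a weaker effect and higher numbers for a stronger effect at the one concentration tested. Compound 1, `Nc1ccccc1NC(=O)c1ccc(CSC(=S)N2CCN(Cc3ccccn3)CC2)cc1`, is the weaker of the two: in this assay compound 1 gives 23.4%, the lowest of the two numbers recorded so far. Compound 2, `Nc1ccccc1NC(=O)c1ccc(CSC(=S)N2CCc3ccccc32)cc1`, gives 44% in this assay, a result that lies beyond the scatter above that of compound 1. Among the compounds with values here, no step between two measured compounds that differ in a single place is available, so nothing is yet known about how one change moves the read-out.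

Compound 3, `N#Cc1ccc(N2CCN(C(=S)SCc3ccc(C(=O)Nc4ccccc4N)cc3)CC2)cc1`, has not yet been measured. It differs from compound 1 in one place: 4-cyanophenyl in place of (pyridin-2-yl)methyl on an amine nitrogen in a ring. The two measured values give only a weak guide, since compound 2 differs from compound 1 in a different way. Within the data shown here, compound 3 is expected to land somewhere between the two known numbers, with the step of a number 8.6 percentage points higher from compound 1 to compound 3 (within the scatter) estimated as a modest rise, though one that may not exceed the scatter. The expected value for compound 3 in this assay is 32%, within a range from 15% to 52%.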

Compound 3, a percentage reported as inhibition, at one concentration (the size of the read-out at that concentration, not a potency): 34.5%
Compound 3: the middle estimate sits 2.5 percentage points below what was measured, and the stated range covers the measured number.
By their numbers in this assay, from the lowest: compound 1; then compounds 3 and 2 (each within the scatter of the next).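

In this assay, putting 4-cyanophenyl in place of (pyridin-2-yl)methyl on the amine nitrogen in the ring gives a number 11.1 percentage points higher from compound 1 to compound 3 (beyond the scatter), a modest step and the first in this series that comes from a change in one place. It shows that the read-out responds to what sits on this nitrogen, with the rest of the molecule unchanged. The swap alters several things together, since a six-membered aromatic ring with a hetero atom leaves, a ring of carbon only enters, and a nitrile appears, and no measurement of any property of these groups is available to account for the step.

On these data alone, what remains open is which of these differences carries the step: the carbon-only ring, the nitrile, or the loss of the methyl link between the ring and the nitrogen. A plain phenyl or a 4-cyanobenzyl group on the same nitrogen would help separate these, and a carboxylic acid or an amine in place of the nitrile would test whether the read-out depends on the nitrile itself.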